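The source may report more compounds than this note shows. Statements on the series, on what has been measured and on what is new or still open speak of the compounds shown alone.

Measured compounds in a functional assay on the whole organism with Mus musculus as the target, with a stated time of 30 min; on this read-out lower numbers stand for an effect already at smaller amounts and higher numbers for an effect only at larger amounts of compound:
- compound 1 `CCC(=O)N1CCN(S(=O)(=O)c2ccc(F)cc2)CC1`: 0.01 mg/kg
- compound 2 `CCC(=O)N1CCCC(NS(=O)(=O)c2ccc(F)cc2)C1`: 10 mg/kg
- compound 3 `CC(=O)N1CCCC(NS(=O)(=O)c2ccc(F)cc2)C1`: 1 mg/kg

Compound 3 holds the second highest of the three numbers in this assay. Its nearest neighbour is compound 2; the step of a 10-fold lower number from compound 2 to compound 3 (1.00 log units; beyond the scatter) is beyond the scatter and is modest in size. Within the data shown here, the furthest is compound 1, whose number in this assay is much lower than that of compound 3; compound 1 also carries a different core, so no single-change step links them.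

Compound 4 `CC(C)S(=O)(=O)N1CCCC(NS(=O)(=O)c2ccc(F)cc2)C1` differs from compound 3 in one place: isopropylsulfonyl in place of acetyl on an amine nitrogen in a ring. Among the measured compounds shown here, the only measured step touching the same ring nitrogen is a 10-fold lower number from compound 2 to compound 3 (1.00 log units; beyond the scatter), where the group on that nitrogen was trimmed by a single saturated chain carbon and the number fell by a modest amount. For the measured compounds named here, the change to compound 4 is of a different kind: an acetyl is exchanged for an isopropylsulfonyl, and no measured pair shows such an exchange on this core. Going by the values given here, the one measured step says the group on this nitrogen matters, but gives no direction for the new group. The expectation for compound 4 in this assay is therefore a step of no change at the digits printed from compound 3 to compound 4 (within the scatter) that may well stay within the scatter, with wide uncertainty. Compound 4 is estimated at 1 mg/kg, within 0.1 mg/kg to 10 mg/kg.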

Compound 4, minimum effective dose: 10 mg/kg
For compound 4 the middle estimate is 10-fold (1.00 log units) below the measured one; the range from low to high includes it.
By their numbers in this assay, from the lowest: compound 1; then compound 3; then compounds 2 and 4 (each within the scatter of the next).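

In this assay, replacing acetyl with isopropylsulfonyl on the amine nitrogen in the ring gives a 10-fold higher number from compound 3 to compound 4 (1.00 log units; beyond the scatter) and so shows that this position responds to a change of group type as well as to the chain trim seen earlier. Replacing propanoyl with the same isopropylsulfonyl gives no change at the digits printed from compound 2 to compound 4 (within the scatter) in this assay, so these two groups cannot be told apart here, and among compounds 2, 3 and 4 the acetyl of compound 3 alone gives the lower number. No measurement on hand accounts for either step.

On these data alone, it remains open whether a methylsulfonyl, a formyl or a free ring amine on this nitrogen would separate the effect of the sulfonyl link from that of the isopropyl group attached to it. As far as these compounds go, it also remains open whether the order among acetyl, propanoyl and isopropylsulfonyl would hold on the core of compound 1, which gives 0.01 mg/kg with a propanoyl group on its ring nitrogen.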